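The source may hold more compounds than are shown below. What is called first, only, known or untested is meant among the compounds shown, and "the series" means these compounds.

The measured compounds:

Compound 1, `Cn1c(=O)c2c(nc(SCCc3ccc(Br)cc3)n2C)n(C)c1=O`, gives 108000 nM in an assay on microsomes for inhibition of Amine oxidase [flavin-containing] A (Homo sapiens), read by fluorescence and spectrophotometry, with a stated time of 20 min; a higher number here means a weaker inhibitor, a lower number a stronger inhibitor.
Compound 2, `Cn1c(=O)c2c(nc(SCCc3ccc(F)cc3)n2C)n(C)c1=O`, gives 14700 nM in this assay.
Compound 3, `Cn1c(=O)c2c(nc([S+]([O-])CCc3ccc(Br)cc3)n2C)n(C)c1=O`, gives 57300 nM in this assay.

Compounds 1 and 2 share one core and differ in a single place: fluoro in place of bromo on an aromatic carbon. That change gave a 7.3-fold lower number from compound 1 to compound 2 (0.87 log units; beyond the scatter), so compound 2 inhibits more strongly than compound 1.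

Compound 3 carries a different core; how the core of compound 3 differs from the core of compound 1 is not broken down here. The numbers for compound 3 and compound 1 lie within the usual scatter of each other, so nothing can be said about their order. Against compound 2, compound 3 gives a higher number, and that gap lies beyond the scatter.

Compound 4, `Cn1c(=O)c2c(nc([S+]([O-])CCc3ccc(F)cc3)n2C)n(C)c1=O`, has not yet been measured. It stands to compound 3 as compound 2 stands to compound 1: fluoro in place of bromo on an aromatic carbon. The place of the change is described in the same words for both pairs, so this is the same kind of change on a different core. Within the data shown here, the only guide is the single measured step from compound 1 to compound 2, and whether a change carries over from one core to another is not known from these data alone. Among the measured compounds shown here, the expectation for the step from compound 3 to compound 4 is therefore a 5.7-fold lower number from compound 3 to compound 4 (0.76 log units; beyond the scatter), a little smaller than the step seen between compound 1 and compound 2, because the measured value of compound 3 is 57300 nM and only one example of the change is available. Compound 4 is estimated to give 10000 nM in this assay, most likely between 3000 nM and 40000 nM.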

Compound 4, half-maximal inhibitory concentration: 239000 nM
Beside the measured number, compound 4's estimate is 24-fold (1.38 log units) below it; the whole stated range lies below it.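

In this assay, putting fluoro in place of bromo on the aromatic carbon gave a 4.2-fold higher number from compound 3 to compound 4 (0.62 log units; beyond the scatter), so on this core the change weakens inhibition, the opposite of what it did on the core of compound 1. Set side by side, the two steps run in opposite directions, and the gap separating them is larger than repeated measurements would explain: the same change on two cores in this assay, a 7.3-fold lower number (0.87 log units; beyond the scatter) from compound 1 to compound 2 and a 4.2-fold higher number (0.62 log units; beyond the scatter) from compound 3 to compound 4, 31-fold (1.49 log units) apart, beyond the scatter of two such steps

Among these compounds, in this series, then, the effect of this change seen on one core does not carry over to the other, so the result from one pair could not stand in for a measurement on the second; with only two pairs, however, the data do not show why the cores respond differently, nor what the same change would do on any further core.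

Left open is what other groups, such as chloro, methyl or methoxy, would do at the same aromatic carbon on each of the two cores, and whether they would also respond differently from one core to the other. Also open, going by these compounds, is how a longer chain leading to the aromatic ring, or an amine on that ring, would affect inhibition on either core.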